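A few compounds are considered here, and "the series" means these few. Any claim that something is new, unique, unknown or untested is made for them only; others in the source may bear on it.

Two compounds have been measured in an assay on cells with melanin-concentrating hormone receptor 1 (Homo sapiens) as the target, read by radioligand binding; on this read-out lower numbers stand for stronger inhibition and higher numbers for weaker inhibition:

Compound 1, `Nc1ccc2cccc(OCCC(F)(F)F)c2n1`, gives 722 nM.
Compound 2, `CC1CCC(Oc2cccc3ccc(N)nc23)C1`, gives 823 nM.

Compound 2 carries the higher of the two numbers, but only just: the step of a 1.1-fold higher number from compound 1 to compound 2 (0.06 log units; within the scatter) is within the scatter, so compound 1 and compound 2 cannot be told apart on this read-out. That step replaced the group on the ring oxygen of the shared core while leaving the rest of the molecule untouched, and the number barely moved.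

Compound 3, `Nc1ccc2cccc(OCC3CCC3)c2n1`, has not yet been measured. Relative to compound 2 the change is cyclobutylmethyl in place of 3-methylcyclopentyl on an oxygen on an aromatic ring. Within the data shown here, this is again a swap of the group on the ring oxygen, the same kind of change as the one from compound 1 to compound 2, which stayed within the scatter. Among the measured compounds shown here, only that one step bears on the question, and it gives no reason to expect a shift beyond the scatter in either direction. Compound 3 is therefore expected to give about 780 nM, with a likely range from 300 nM to 2000 nM. The expected step is a 1.1-fold lower number from compound 2 to compound 3 (0.02 log units; within the scatter).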

Compound 3, half-maximal inhibitory concentration: 432 nM
Compound 3: the middle estimate sits 1.8-fold (0.26 log units) above what was measured; the range from low to high includes it.
By their numbers in this assay, from the lowest: compounds 3, 1 and 2 (each within the scatter of the next).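

In this assay, a third group on the oxygen on an aromatic ring also stays within the scatter: putting cyclobutylmethyl in place of 3-methylcyclopentyl gives a 1.9-fold lower number from compound 2 to compound 3 (0.28 log units; within the scatter), and the comparison with the trifluorinated chain gives a 1.7-fold lower number from compound 1 to compound 3 (0.22 log units; within the scatter). With the earlier step, this means that a fluorine-bearing chain, a five-membered carbon ring with a methyl group and a four-membered carbon ring on a short link cannot be told apart on this read-out, even though the change from 3-methylcyclopentyl to cyclobutylmethyl alters both the ring size and the heavy-atom count, from 6 to 5. No other measurement is available to explain this result.

As far as these compounds go, whether any group on this oxygen can move the number beyond the scatter, in either direction, remains open. The three groups shown also leave open what an amine or a carboxylic acid at the end of a longer chain would do at this position.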